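Replacing the 2-nitrophenyl group with 4-chlorophenyl

The source may hold more compounds than are shown below. What is called first, only, known or untested is meant among the compounds shown, and "the series" means these compounds.

In a functional assay on K562 cells (Homo sapiens) for cytotoxicity, read by sulforhodamine B assay (on this read-out lower numbers stand for stronger inhibition of growth and higher numbers for weaker inhibition of growth), compound 1 (`CC1=CC[C@@H]([C@@](C)(O)CCCC(C)(C)NC(=S)NN)CC1`) gives 20 nM, compound 2 (`CC1=CC[C@@H]([C@@](C)(O)CCCC(C)(C)NC(=S)N/N=C\c2ccc(O)cc2)CC1`) gives 600 nM, and compound 3 (`CC1=CC[C@@H]([C@@](C)(O)CCCC(C)(C)NC(=S)N/N=C\c2ccccc2[N+](=O)[O-])CC1`) gives 190 nM, the middle of the three numbers. Compound 4 (`CC1=CC[C@@H]([C@@](C)(O)CCCC(C)(C)NC(=S)N/N=C\c2ccc(Cl)cc2)CC1`) carries 4-chlorophenyl in place of 2-nitrophenyl on a carbon with a double bond to nitrogen. For the measured compounds named here, the closest precedent is the exchange at the same place, which shows a 3.2-fold lower number from compound 2 to compound 3 (0.50 log units; beyond the scatter), a modest step. The large 30-fold higher number from compound 1 to compound 2 (1.48 log units; beyond the scatter) introduces the aromatic ring and bears less directly. A small step towards a higher number in this assay is expected, probably within the scatter. The estimated step is a 1.3-fold higher number from compound 3 to compound 4 (0.12 log units; within the scatter). For compound 4 the expected value is 250 nM, with an estimated range of 90 nM to 700 nM.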

Compound 4, concentration for 50% growth inhibition: 40 nM
Beside the measured number, compound 4's estimate is 6.3-fold (0.80 log units) above it; measured number below the stated range.
By their numbers in this assay, from the lowest: compounds 1 and 4 (each within the scatter of the next); then compound 3; then compound 2.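

In this assay, the group on a carbon with a double bond to nitrogen strongly sets the number: 4-chlorophenyl in place of 2-nitrophenyl gives a 4.8-fold lower number from compound 3 to compound 4 (0.68 log units; beyond the scatter), and chloro in place of hydroxy on an aromatic carbon gives a 15-fold lower number from compound 2 to compound 4 (1.18 log units; beyond the scatter). The aromatic ring does not always carry a large cost, as a 2.0-fold higher number from compound 1 to compound 4 (0.30 log units; within the scatter) contrasts with a 30-fold higher number from compound 1 to compound 2 (1.48 log units; beyond the scatter). No measurement here explains these differences.

Open, as far as these compounds go, is whether the result follows the chloro group or the substitution pattern: 2-chlorophenyl and 4-nitrophenyl would separate the two.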